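Fluoro for Methoxy on an Amide Series Inactive in Raji Cells

The compounds below may be only part of what the source reports. "The series", "measured", "known", "first", "only" and "open" are said of these compounds alone.

Compound 1 `O=C(Nc1cc(-c2nc3ccccc3o2)ccc1F)c1cc([N+](=O)[O-])ccc1Cl`, compound 2 `COc1ccc(-c2nc3ccccc3s2)cc1NC(=O)c1cc([N+](=O)[O-])ccc1Cl` and compound 3 `O=C(Nc1cccc(-c2nc3ccccc3s2)c1)c1cc([N+](=O)[O-])c(O)cc1Cl` share one core, with small changes to the groups on their aromatic rings. In an ADME assay on Raji cells (Homo sapiens) for cytotoxicity, with a stated time of 72 h (a higher number here means that more compound is needed for the effect, a lower number that less compound is needed), compound 1 gives > 25000 nM, which is a limit of the assay and not a number. Compound 2 gives > 25000 nM in this assay, again only a limit. Compound 3 gives > 25000 nM in this assay, also a limit. Compound 2 therefore stands where every measured compound stands, at the limit of > 25000 nM in this assay, at which 3 of the 3 values shown sit, so nothing here separates it from its neighbours.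

Compound 4 `O=C(Nc1cc(-c2nc3ccccc3s2)ccc1F)c1cc([N+](=O)[O-])ccc1Cl` has not yet been measured. It differs from compound 2 by fluoro in place of methoxy on an aromatic carbon.

Going by the values given here, no step between measured compounds is known in this set. The step that the estimate implies, a step that the limit leaves unreadable from compound 2 to compound 4, is expected to be none beyond the usual scatter. Compound 4 is therefore expected to give about 30000 nM in this assay, within a range from 10000 nM to 100000 nM, and most likely to be reported once more as a limit rather than a number.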

Compound 4, half-maximal effective concentration: > 25000 nM
Compound 4 was reported as a limit; the forecaster's own chance of this, stated with the estimate: 85%; the middle value lies beyond the limit too.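

Compound 4 sits at a limit of the assay, as do compound 1 and compound 2, so no step can be read from compound 2 or compound 1 to compound 4: the limit of > 25000 nM in this assay, at which 4 of the 4 values shown sit.

The compounds shown leave open whether either change, fluoro for methoxy or 1,3-benzothiazol-2-yl for 1,3-benzoxazol-2-yl, has any effect in this assay.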